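Swapping 4-methylphenyl for ethoxycarbonyl on compound 3

The compounds below may be only part of what the source reports. "The series", "measured", "known", "first", "only" and "open" are said of these compounds alone.

In a functional assay on MV4-11 cells (Homo sapiens) for antiproliferative activity, read by luminescence and CellTiter-Glo, with a stated time of 72 h (a lower number here means a stronger inhibitor, a higher number a weaker inhibitor), three compounds have been measured so far. Compound 1 `COc1cc(Nc2nn(C3CCCCO3)c3cc(-c4c(C)noc4C)ccc23)ccc1F` gives 9300 nM, and compound 2 `COc1ccc(Cn2nc(Nc3ccc(F)cc3)c3ccc(-c4c(C)noc4C)cc32)cc1` gives 9100 nM. Compound 3 `CNc1cc(-c2ccc3cnn(Cc4ccc(C)cc4)c3c2)cn(C)c1=O` gives 3280 nM, the lowest of the three and beyond the scatter from both others. Compound 4 `CCOC(=O)Cn1ncc2ccc(-c3cc(NC)c(=O)n(C)c3)cc21` has not yet been measured. It keeps the core of compound 3 and changes one group: ethoxycarbonyl in place of 4-methylphenyl on a saturated chain carbon bound to an aromatic nitrogen, on a saturated chain carbon bound to an aromatic nitrogen. Within the data shown here, no measured pair isolates a single change, so any forecast here is loose. In this assay the expected step is a 2.7-fold higher number from compound 3 to compound 4 (0.44 log units; beyond the scatter), moderately toward a weaker inhibitor and beyond the scatter. For compound 4 the estimated value is 9000 nM, with an expected range of 3000 nM to 30000 nM.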

Compound 4, half-maximal inhibitory concentration: 8770 nM
The estimate for compound 4 lay 1.0-fold (0.01 log units) above the measured number, within the range that was stated.
By their numbers in this assay, from the lowest: compound 3; then compounds 4, 2 and 1 (each within the scatter of the next).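

Among these compounds, compound 3 and compound 4 form the only pair here that differs in one place. In this assay, ethoxycarbonyl in place of 4-methylphenyl on a saturated chain carbon bound to an aromatic nitrogen gives a 2.7-fold higher number from compound 3 to compound 4 (0.43 log units; beyond the scatter) and so shows that the number responds to the group at this position. No measurement shown explains this step. From the compounds shown here alone, whether a carboxylic acid, an amine or a plain phenyl on that carbon would stay nearer compound 3 remains open.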